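Swapping the terminal aryl ring of a quinazoline urea

The compounds below may be only part of what the source reports. "The series", "measured", "known", "first", "only" and "open" are said of these compounds alone.

Two compounds have been measured in a functional assay on MGC-803 cells (Homo sapiens) for antiproliferative activity, read by MTT assay; a lower number here means a stronger inhibitor, a higher number a weaker inhibitor:

Compound 1, `COc1cc2ncnc(NCc3cccc(NC(=O)Nc4cccc(C)c4)c3)c2cc1OC`, gives 44600 nM.
Compound 2, `COc1cc2ncnc(NCc3cccc(NC(=O)Nc4ccc(F)cc4)c3)c2cc1OC`, gives 42100 nM.

Compound 2 holds the lower of the two numbers, but only just: the step of a 1.1-fold lower number from compound 1 to compound 2 (0.03 log units; within the scatter) lies within the scatter of the measurement, so the two compounds cannot be told apart on these data. Both numbers are high, meaning neither compound inhibits the cells strongly.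

Compound 3, `COc1cc2ncnc(NCc3cccc(NC(=O)Nc4cccc(C(F)(F)F)c4)c3)c2cc1OC`, has not yet been measured. It differs from compound 2 by 3-(trifluoromethyl)phenyl in place of 4-fluorophenyl on an amide-type nitrogen. For the measured compounds named here, the one measured step that bears on this, a 1.1-fold lower number from compound 1 to compound 2 (0.03 log units; within the scatter), also exchanged the aryl group on that same amide-type nitrogen, and it produced no change beyond the scatter. Going by the values given here, with only that step to go on, compound 3 is expected to show no step beyond the scatter either, a 1.1-fold lower number from compound 2 to compound 3 (0.02 log units; within the scatter).

Compound 3 is therefore estimated at 40000 nM, with a range from 15000 nM to 100000 nM.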

Compound 3, half-maximal inhibitory concentration: > 50000 nM
Compound 3: no number, only a limit (the forecaster's own chance of this, stated with the estimate: 15%); at least 1.2-fold (0.09 log units) between middle value and limit.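

Compound 3 gives > 50000 nM in this assay, which is a limit of the assay and not a number: the limit of > 50000 nM in this assay, at which 1 of the 3 values shown sits.

Read as floors only, the new steps are an at least 1.1-fold higher number from compound 2 to compound 3 (0.07 log units; that floor lies within the scatter) and an at least 1.1-fold higher number from compound 1 to compound 3 (0.04 log units; that floor lies within the scatter), so neither is shown to pass beyond the scatter, and the true distance from compound 3 to the other two stays unknown. What this adds is a third aryl group on the same amide-type nitrogen: 3-(trifluoromethyl)phenyl does not give a lower number than 4-fluorophenyl or 3-methylphenyl, and trifluoromethyl in place of methyl on the aromatic carbon does not give one either, so all three compounds remain weak inhibitors in this assay.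

The compounds shown leave open whether any other group at this position can bring the number down clearly, for example a phenyl ring carrying a methoxy group, an amine or a carboxylic acid, or a pyridine ring in place of the phenyl ring. They also leave open whether a change away from this terminal ring, such as a longer chain in place of the link to the shared core, would matter more than these aryl swaps.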